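Cyclopropylmethyl in place of propyl on compound 1

The compounds below may be only part of what the source reports. "The series", "measured", "known", "first", "only" and "open" are said of these compounds alone.

Measured in a functional assay on K562 cells (Homo sapiens) for inhibition, read by trypan blue exclusion, with a stated time of 72 h; a lower number here means a stronger inhibitor, a higher number a weaker inhibitor:
- compound 1 `CCCn1c(=O)c(S(=O)(=O)c2ccc(F)cc2F)cc2cnc(Nc3ccc4[nH]ccc4c3)nc21`: 1000 nM
- compound 2 `Cn1c(=O)c(S(=O)(=O)c2ccc(F)cc2)cc2cnc(Nc3ccc4[nH]ncc4c3)nc21`: 10000 nM
- compound 3 `Cn1c(=O)c(S(=O)(=O)c2ccc(Cl)cc2)cc2cnc(Nc3cccc4[nH]ccc34)nc21`: 5000 nM

Compound 1 holds the lowest of the three numbers, and so is the strongest inhibitor of this small set. Compound 3 at 5000 nM and compound 2 at 10000 nM both lie beyond the scatter from it. For the measured compounds named here, these three compounds differ from one another in more than one place, so no measured pair isolates a single change, and none speaks directly to the substituent in question here.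

The next compound is compound 4 `O=c1c(S(=O)(=O)c2ccc(F)cc2F)cc2cnc(Nc3ccc4[nH]ccc4c3)nc2n1CC1CC1`, which departs from compound 1 in one place only: cyclopropyl in place of ethyl on a saturated chain carbon bound to an aromatic nitrogen. In words, this is cyclopropyl in place of ethyl on a saturated chain carbon bound to an aromatic nitrogen. Cut one bond further out, the same difference reads propyl to cyclopropylmethyl.

Going by the values given here, with no measured precedent for this change, the starting point is compound 1 at 1000 nM and no step beyond the scatter is expected in this assay. The estimated step (no change at the digits printed from compound 1 to compound 4 (within the scatter)) is therefore small, and its direction is left open. The estimated value for compound 4 is 1000 nM (expected range 300 nM to 3500 nM).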

Compound 4, half-maximal inhibitory concentration: 1000 nM
The estimate for compound 4 equals the measured number at the digits printed, within the range that was stated.
By their numbers in this assay, from the lowest: compounds 1 and 4 (each within the scatter of the next); then compounds 3 and 2 (each within the scatter of the next).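

In this assay, for the compounds shown here, this is the first comparison that isolates a single change: cyclopropyl in place of ethyl on a saturated chain carbon bound to an aromatic nitrogen gives no change at the digits printed from compound 1 to compound 4 (within the scatter). The earlier compounds shown here could not speak to this place, since compounds 2 and 3 carry methyl there but also differ from compound 1 elsewhere; this pair shows that, with the rest of compound 1 held fixed, the place takes cyclopropylmethyl as readily as propyl, with the extra carbon and the three-membered non-aromatic ring leaving the read-out within the scatter. No measured evidence accompanies this pair to say why the two groups read alike.

As far as these compounds go, it remains open whether this place stays as permissive for a longer chain such as butyl, or for a chain ending in an amine or a carboxylic acid, since both groups compared here contain carbon only. From the compounds shown here alone, the effect of shortening the chain to methyl with the rest of compound 1 held fixed also remains open, as does whether the equivalence of propyl and cyclopropylmethyl carries over to the other parts of the molecule seen in compounds 2 and 3.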